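The source may hold more compounds than are shown below. What is called first, only, known or untested is meant among the compounds shown, and "the series" means these compounds.

In a functional assay on RAW264.7 cells (Mus musculus) for inhibition, read by Griess assay, with stated times of 2 h and 24 h (on this read-out higher numbers stand for weaker inhibition and lower numbers for stronger inhibition), the three measured compounds stand as follows:
Compound 1 `COc1ccc([C@@H]2CC(=O)c3c(O)cc(OCc4cn(Cc5ccc(Cl)cc5)nn4)cc3O2)cc1O` gives 17800 nM.
Compound 2 `COc1ccc([C@@H]2CC(=O)c3c(O)cc(OCc4cn(Cc5ccccc5)nn4)cc3O2)cc1O` gives 11000 nM.
Compound 3 `COc1ccc([C@@H]2CC(=O)c3c(O)cc(OCc4cn(Cc5cccc(C#N)c5)nn4)cc3O2)cc1O` gives 18000 nM.

Compound 3 has the highest of these three numbers, yet it is not separated from the others: a 1.0-fold higher number from compound 1 to compound 3 (0.00 log units; within the scatter) and a 1.6-fold higher number from compound 2 to compound 3 (0.21 log units; within the scatter). Compound 2 differs from compound 1 in the same way, since a 1.6-fold lower number from compound 1 to compound 2 (0.21 log units; within the scatter). Across these three compounds, changing the group on the benzyl ring therefore leaves the read-out in this assay essentially unchanged.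

Among the compounds with values here, compound 4 `COc1ccc([C@@H]2CC(=O)c3c(O)cc(OCc4cn(C5CCCCC5)nn4)cc3O2)cc1O` has not yet been measured. cyclohexyl in place of 3-cyanobenzyl on an aromatic nitrogen None of the measured steps exchanges the benzyl group for a ring that is not aromatic, so the earlier steps bear on this change only loosely. They show that varying the group attached to the triazole nitrogen has so far stayed inside the scatter, and the expectation for compound 4 is accordingly no step beyond the scatter, a 1.2-fold lower number from compound 3 to compound 4 (0.08 log units; within the scatter). Compound 4 is estimated to give 15000 nM in this assay, with a range from 6000 nM to 40000 nM.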

Compound 4, half-maximal inhibitory concentration: 15600 nM
For compound 4 the middle estimate is 1.0-fold (0.02 log units) below the measured one; measured number inside the range.
By their numbers in this assay, from the lowest: compounds 2, 4, 1 and 3 (each within the scatter of the next).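

Putting cyclohexyl on the aromatic nitrogen gives, in this assay, a 1.2-fold lower number from compound 3 to compound 4 (0.06 log units; within the scatter), a 1.4-fold higher number from compound 2 to compound 4 (0.15 log units; within the scatter) and a 1.1-fold lower number from compound 1 to compound 4 (0.06 log units; within the scatter). The earlier compounds shown here changed only a group on the benzyl ring, whereas this change replaces the whole benzyl unit with a six-membered non-aromatic ring of carbon only, and the read-out still stays within the scatter, so an aromatic ring at this position is not needed to keep it there. No measurement is available here to explain this insensitivity.

As far as these compounds go, it remains open whether a group of another kind at this position, such as an amine, a carboxylic acid or a longer chain, would move the number beyond the scatter. With all four compounds within the scatter of one another, they do not show what at this position, if anything, can change the read-out.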